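The source may hold more compounds than are shown below. What is called first, only, known or untested is meant among the compounds shown, and "the series" means these compounds.

In a functional assay on HepG2 cells (Homo sapiens) for antiproliferative activity, read by fluorescence and resazurin assay, with a stated time of 48 h (a lower number here means a stronger inhibitor, a higher number a weaker inhibitor), compound 1 (`CCOc1ccc(NC(=O)c2cc3ccc(O)cc3oc2=O)cc1`) gives 17300 nM and compound 2 (`CCOc1ccc(NC(=O)c2cc3cc([N+](=O)[O-])ccc3oc2=O)cc1`) gives 28300 nM as its reading. These two numbers lie within the usual scatter of each other, so compound 2 stands level with compound 1. Compound 3 (`CCOc1ccc(NC(=O)c2cc3ccccc3oc2=O)cc1`) differs from compound 2 by one change (hydrogen in place of nitro on an aromatic carbon), hydrogen in place of nitro on an aromatic carbon. Compound 1 (17300 nM) and compound 2 (28300 nM) carry different groups on the shared core yet read alike, so no step beyond the scatter is expected in this assay here. The expected 1.3-fold lower number from compound 2 to compound 3 (0.11 log units; within the scatter) (an estimate) stays within that scatter. Compound 3 is estimated at 22000 nM (range 10000 nM to 50000 nM).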

Compound 3, half-maximal inhibitory concentration: 10400 nM
The estimate for compound 3 lay 2.1-fold (0.33 log units) above the measured number; the measured number falls inside the stated range.
By their numbers in this assay, from the lowest: compounds 3, 1 and 2 (each within the scatter of the next, the first and the last beyond it).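

In this assay, for the compounds shown here, hydrogen in place of nitro on this aromatic carbon gives a 2.7-fold lower number from compound 2 to compound 3 (0.43 log units; beyond the scatter) and is the first step here beyond the scatter, so this position does respond to what it carries, with hydrogen reading better than nitro. Hydrogen in place of hydroxy on an aromatic carbon gives a 1.7-fold lower number from compound 1 to compound 3 (0.22 log units; within the scatter) and stays within the scatter, so that change shows no clear effect. As far as these compounds go, whether an amine or a methoxy group at the nitro position would read lower than hydrogen stays open. Nothing shown here explains the gap between nitro and hydrogen.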